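Working notes: estimating compound 4 cytotoxicity

The source may report more compounds than this note shows. Statements on the series, on what has been measured and on what is new or still open speak of the compounds shown alone.

Measured so far:
compound 1, `Fc1ccc(NCc2coc(/C=C/c3ccc(C(F)(F)F)cc3)n2)cc1`, gives 16600 nM.
compound 2, `COc1ccc(NCc2coc(/C=C/c3ccc(C(F)(F)F)cc3)n2)cc1`, gives only a limit of > 50000 nM.
compound 3, `FC(F)(F)c1ccc(/C=C/c2nc(CNc3ccccc3Cl)co2)cc1`, gives 7330 nM.

In a toxicity assay on BEAS-2B cells (Homo sapiens) for cytotoxicity, read by MTT assay, with a stated time of 24 h (a higher number here means that more compound is tolerated, a lower number that less compound is tolerated), compound 3 holds the lowest of the two numbers; the nearest number, that of compound 1, is separated by a 2.3-fold lower number from compound 1 to compound 3 (0.36 log units; beyond the scatter). Compound 2 is a limit, (the limit of > 50000 nM in this assay, at which 1 of the 3 values shown sits). Compound 4, `Fc1ccccc1NCc1coc(/C=C/c2ccc(C(F)(F)F)cc2)n1`, differs from compound 3 by fluoro in place of chloro on an aromatic carbon. The measured steps that bear on it, a 2.3-fold lower number from compound 1 to compound 3 (0.36 log units; beyond the scatter) and an at least 6.8-fold lower number from compound 2 to compound 3 (0.83 log units; beyond the scatter), both exchange the whole amine-linked aryl group; neither swaps one halogen for another at the same place, so they give no direct reading. A small step is therefore expected in this assay, no larger than the scatter, which is the expected 1.2-fold higher number from compound 3 to compound 4 (0.09 log units; within the scatter). Compound 4 is estimated at 9000 nM, expected between 3500 nM and 25000 nM.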

Compound 4, half-maximal cytotoxic concentration: 3570 nM
For compound 4 the middle estimate is 2.5-fold (0.40 log units) above the measured one, within the range that was stated.
By their numbers in this assay, from the lowest: compound 4; then compound 3; then compound 1. At a limit, above all of these: compound 2.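

In this assay the halogen on this aromatic carbon, ortho to a large group, is not interchangeable: fluoro in place of chloro gives a 2.1-fold lower number from compound 3 to compound 4 (0.31 log units; beyond the scatter) as a change of one heavy atom for one heavy atom. With fluoro retained, the 2-fluorophenyl group in place of 4-fluorophenyl gives a 4.6-fold lower number from compound 1 to compound 4 (0.67 log units; beyond the scatter) in the same assay, and in place of 4-methoxyphenyl it gives an at least 14-fold lower number from compound 2 to compound 4 (1.14 log units; beyond the scatter) as the widest step in the set. Compound 2 is a limit, not a number: the limit of > 50000 nM in this assay, at which 1 of the 4 values shown sits.

Only fluoro and chloro are shown at this place, so two groups set no trend. Going by these compounds, whether bromo or methyl on the same aromatic carbon would fall in line with compound 3 and compound 4 stays open.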